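Notes on adding a second fluoro to compound 2

A few compounds are considered here, and "the series" means these few. Any claim that something is new, unique, unknown or untested is made for them only; others in the source may bear on it.

In a functional assay on OVCAR-8 cells (Homo sapiens) for antiproliferative activity, read by MTT assay, with a stated time of 72 h (on this read-out higher numbers stand for weaker inhibition and lower numbers for stronger inhibition), compound 1 (`O=C(Nc1ccccn1)c1cc(=O)[nH]c2cc(Br)ccc12`) gives > 20000 nM, which is a limit and not a number. Going by the values given here, compound 2 (`O=C(Nc1cccc(F)c1)c1cc(=O)[nH]c2cc(Br)ccc12`) gives 5800 nM, the only true number so far.

Compound 3 (`O=C(Nc1cc(F)cc(F)c1)c1cc(=O)[nH]c2cc(Br)ccc12`) differs from compound 2 by fluoro in place of hydrogen on an aromatic carbon, meta to a fluoro group: fluoro in place of hydrogen on an aromatic carbon.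

Among the compounds with values here, only one measured step bears on this, and only loosely: an at least 3.4-fold lower number from compound 1 to compound 2 (0.53 log units; beyond the scatter). Within the data shown here, it exchanges pyridin-2-yl for 3-fluorophenyl on an amide-type nitrogen, a whole-group swap, and no measured step isolates a single fluoro. Little change is therefore expected in this assay, with at most a slight lean towards lower numbers. The estimated step is a 1.3-fold lower number from compound 2 to compound 3 (0.11 log units; within the scatter), probably within the scatter. The expected value for compound 3 is 4500 nM, with an estimated range of 1800 nM to 12000 nM.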

Compound 3, half-maximal inhibitory concentration: 12100 nM
For compound 3 the middle estimate is 2.7-fold (0.43 log units) below the measured one; measured number outside the range, above it.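

In this assay, going by these compounds alone, the second fluoro gives a 2.1-fold higher number from compound 2 to compound 3 (0.32 log units; beyond the scatter), the first step that isolates a single fluoro on the six-membered aromatic ring. This position, meta to a fluoro group, therefore does not take fluoro in place of hydrogen without a cost, and the improvement of the earlier whole-group swap, an at least 3.4-fold lower number from compound 1 to compound 2 (0.53 log units; beyond the scatter), does not carry over to a second fluoro. Compound 1 stands at a limit and not at a number, which also caps how far any further loss in this series can be read: the limit of > 20000 nM in this assay, at which 1 of the 3 values shown sits.

Within the data shown here, the single pair gives no reason for the loss and cannot show whether it is specific to fluoro. A chloro, methoxy or amino group at the same position would show whether the loss follows fluoro alone or any group placed there.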